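This account rests on a few compounds, and the source may have more. Where it says the series, first, only, none or still open, it means among the compounds named here.

Measured in an ADME assay on cells (Homo sapiens) for activation; on this read-out lower numbers stand for higher toxicity in this test and higher numbers for lower toxicity in this test:
- compound 1 `CCCn1cc(-c2cc(OCC[C@@H]3NC(=O)N(C)CCCC/C=C\[C@@H]4C[C@@]4(C(=O)NS(=O)(=O)C4(C)CC4)NC3=O)c3ccc(OC)c(C)c3n2)cn1` — 62300 nM
- compound 2 `COc1ccc2c(OCC[C@@H]3NC(=O)N(C)CCCC/C=C\[C@@H]4C[C@@]4(C(=O)NS(=O)(=O)C4(C#N)CC4)NC3=O)cc(-c3nc(C(C)C)cs3)nc2c1Cl` — a limit of the assay, > 75000 nM
- compound 3 `COc1ccc2c(OCC[C@@H]3NC(=O)N(C)CCCC/C=C\[C@@H]4C[C@@]4(C(=O)NS(=O)(=O)C4CC4)NC3=O)cc(-c3nc(C(C)C)cs3)nc2c1Cl` — 40400 nM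

Compound 2 gives only a limit in this assay. Of the two numbers, compound 1 is the one at the top, but compound 3 sits within the scatter of it, so the two cannot be told apart. Within the data shown here, the one step measured, an at least 1.8-fold lower number from compound 2 to compound 3 (0.26 log units; that floor lies within the scatter), concerns hydrogen in place of cyano on a saturated ring carbon and rests on the limit (the limit of > 75000 nM in this assay, at which 1 of the 3 values shown sits); it does not touch the place changed here.

Compound 4 `COc1ccc2c(OCC[C@@H]3NC(=O)N(C)CCCC/C=C\[C@@H]4C[C@@]4(C(=O)NS(=O)(=O)C4(C)CC4)NC3=O)cc(-n3ccc(C(C)C)n3)nc2c1C` differs from compound 1 by 3-isopropyl-1H-pyrazol-1-yl in place of 1-propyl-1H-pyrazol-4-yl on an aromatic carbon. Among the measured compounds shown here, no measured step bears on this change. With the two numbers in hand close together and one value a limit, the step expected is a 1.0-fold lower number from compound 1 to compound 4 (0.02 log units; within the scatter), which stays within the scatter. Compound 4 is therefore expected at 60000 nM, within 30000 nM to 120000 nM, with a fair chance that this assay again reports only a limit.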

Compound 4, half-maximal cytotoxic concentration: 25600 nM
The estimate for compound 4 lay 2.3-fold (0.37 log units) above the measured number; measured number below the stated range.
By their numbers in this assay, from the lowest: compounds 4, 3 and 1 (each within the scatter of the next, the first and the last beyond it). At a limit, above all of these: compound 2.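

In this assay, 3-isopropyl-1H-pyrazol-1-yl in place of 1-propyl-1H-pyrazol-4-yl gives a 2.4-fold lower number from compound 1 to compound 4 (0.39 log units; beyond the scatter), the first step measured at this aromatic carbon next to the ring nitrogen. The two groups have the same atoms, joined differently, and the same counts of hydrogen-bond donors and acceptors, so this position responds to rearrangement alone, without any change in composition. Nothing measured here accounts for the step.

The compounds shown do not separate the change in ring attachment from the change from propyl to isopropyl; a 3-propyl-1H-pyrazol-1-yl group would address that. Going by these compounds, how this position responds to a pyrazole carrying an amine or a carboxylic acid also remains open.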